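The compounds below may be only part of what the source reports. "The series", "measured", "known", "first", "only" and "open" are said of these compounds alone.

Three compounds share one core and differ only in the group carried on the amide-type nitrogen of a side chain. Compound 1 `CCOC(=O)C1=C(C)NC(C)=C(C(=O)OCC)C1c1ccc(OCC(=O)NCc2ccccc2)cc1` carries a benzyl group there; compound 2 `CCOC(=O)C1=C(C)NC(C)=C(C(=O)OCC)C1c1ccc(OCC(=O)Nc2nc3ccccc3s2)cc1` a 1,3-benzothiazol-2-yl group; compound 3 `CCOC(=O)C1=C(C)NC(C)=C(C(=O)OCC)C1c1ccc(OCC(=O)NNC(=O)c2ccccc2)cc1` a benzamido group. In a functional assay on the whole organism (strain Wistar) for inhibition, with Rattus norvegicus as the target, read by paw edema, with stated times of 30 min and 1 h, at a dose of 20 mg/kg (a higher number here means more inhibition at the dose given (going by the name of the read-out), a lower number less inhibition), compound 1 gives 16.1%, compound 2 gives 54.5% and compound 3 gives 29.5%. Compound 3 thus stands second highest of the three, with compound 1 its nearest neighbour a number 13.4 percentage points higher from compound 1 to compound 3 (beyond the scatter) and compound 2 furthest away a number 25 percentage points lower from compound 2 to compound 3 (beyond the scatter).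

Compound 4 `CCOC(=O)C1=C(C)NC(C)=C(C(=O)OCC)C1c1ccc(OCC(=O)n2nc(C)cc2C)cc1` is not yet measured. Its change from compound 3 is 3,5-dimethyl-1H-pyrazol-1-yl in place of benzamidoamino on a carbonyl carbon. Both measured steps into compound 3 bear on this: they show that swapping the group beyond the carbonyl moves the read-out beyond the scatter in either direction, by a number 13.4 percentage points higher from compound 1 to compound 3 (beyond the scatter) and by a number 25 percentage points lower from compound 2 to compound 3 (beyond the scatter). None of them, however, removes the amide-type nitrogen itself, as the present change does, so direction is uncertain. A ring with two hetero atoms gave the highest number in compound 2, which weighs against expecting a large fall. The expected step is therefore small, a number 2.5 percentage points higher from compound 3 to compound 4 (within the scatter), within the scatter. Compound 4 is estimated at 32% in this assay, with a range from 14% to 52%.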

Compound 4, a percentage reported as inhibition, in the whole organism at one dose (the size of the read-out at that dose, not a potency): 32.7%
Compound 4: middle estimate off by 0.7 percentage points, on the low side; the measured number falls inside the stated range.
By their numbers in this assay, from the lowest: compound 1; then compounds 3 and 4 (each within the scatter of the next); then compound 2.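

In this assay, replacing benzamidoamino on the carbonyl carbon with 3,5-dimethyl-1H-pyrazol-1-yl takes away the amide-type nitrogen and its hydrogen, leaving a group with 0 hydrogen-bond donors, yet the two compounds cannot be told apart: a number 3.2 percentage points higher from compound 3 to compound 4 (within the scatter). A hydrogen on that nitrogen is therefore not required for a reading at this level, while the same swap still separates the new compound clearly from the other two, with a number 16.6 percentage points higher from compound 1 to compound 4 (beyond the scatter) and a number 21.8 percentage points lower from compound 2 to compound 4 (beyond the scatter), so the group on this carbonyl continues to matter. Nothing available explains these differences in terms of a measured property of the groups.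

Going by these compounds, it remains open whether the two methyl groups contribute to the number seen for compound 4, a question that the unsubstituted pyrazol-1-yl group on the same carbonyl would address. On these data alone, it is also open how a simple amine such as morpholin-4-yl, or a plain carboxylic acid in place of the whole amide-type unit, would read in this assay.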